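The compounds below may be only part of what the source reports. "The series", "measured", "known", "first", "only" and "open" are said of these compounds alone.

Measured in an ADME assay on HepG2 cells (Homo sapiens) for cytotoxicity, read by resazurin assay, with a stated time of 48 h; a higher number here means that more compound is needed for the effect, a lower number that less compound is needed:
- Compound 1 `O=C(Nc1ccc(F)c(-c2nc3ncc(-c4ccc(F)c(F)c4)cc3[nH]2)c1)N1CCCC1`: > 50000 nM, a limit and not a number
- Compound 2 `O=C(Nc1ccc(F)c(-c2nc3ncc(-c4cccnc4F)cc3[nH]2)c1)N1CCCC1`: > 50000 nM, a limit and not a number
- Compound 3 `O=C(Nc1ccc(F)c(-c2nc3ncc(-c4cccc(F)c4)cc3[nH]2)c1)N1CCCC1`: 28200 nM

Compound 3, at 28200 nM, is the only one of the three with a real number. The other two stand at the limit of > 50000 nM in this assay, at which 2 of the 3 values shown sit.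

Compound 4 `O=C(Nc1ccc(F)c(-c2nc3ncc(-c4ccccc4F)cc3[nH]2)c1)N1CCCC1` has not been measured yet. It has the same atoms as compound 3, joined differently: 2-fluorophenyl in place of 3-fluorophenyl on an aromatic carbon.

Three measured steps change the group at this same place. Swapping one whole group gives an at least 1.7-fold lower number from compound 2 to compound 3 (0.24 log units; that floor lies within the scatter). Replacing a single fluoro with hydrogen gives an at least 1.7-fold lower number from compound 1 to compound 3 (0.24 log units; that floor lies within the scatter). Both sizes are only floors, so the real steps could be larger. The third step is a step that the two limits leave unreadable from compound 1 to compound 2, and it adds no size. None of these steps moves a fluoro around the ring, so the evidence is indirect. With so little to go on, no step beyond the scatter is expected in this assay.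

The expected change is a 1.1-fold higher number from compound 3 to compound 4 (0.03 log units; within the scatter). Compound 4 is estimated at 30000 nM, with an expected range from 15000 nM to 50000 nM.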

Compound 4, half-maximal effective concentration: > 50000 nM
Compound 4 gave a limit, no number; the forecaster's own chance of this, stated with the estimate: 35%; middle value at least 1.6-fold (0.22 log units) from the limit.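

Moving the single fluoro on this ring, with 2-fluorophenyl in place of 3-fluorophenyl, gives an at least 1.7-fold higher number from compound 3 to compound 4 (0.24 log units; that floor lies within the scatter) in this assay; the earlier steps swapped a whole group or removed a fluoro, so this is the first direct test of where the fluoro sits, though the floor alone does not establish a real difference. For the compounds shown here, only one compound now gives a readable number, while the other three share a single ceiling: the limit of > 50000 nM in this assay, at which 3 of the 4 values shown sit. The steps from compound 1 and from compound 2 to compound 4 cannot be read, since both ends of each step are limits, so nothing can be said about the order of these three compounds.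

As far as these compounds go, how far compounds 1, 2 and 4 lie beyond that limit stays unknown, and so does whether the gap between compound 3 and compound 4 is larger than its floor. Also open, from the compounds shown here alone, is what a plain phenyl, a 4-fluorophenyl, or a phenyl carrying an amine or a carboxylic acid at this place would give in this assay.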